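Opening a long protected side chain at the amino acid carbon

The source may report more compounds than this note shows. Statements on the series, on what has been measured and on what is new or still open speak of the compounds shown alone.

Measured so far in a functional assay on the whole organism (Tail, strain ICR) with Mus musculus as the target, in the tail flick test, with a stated time of 90 min, at a dose of 25 umol/kg by the oral route; a higher number here means a stronger effect of the compound at the dose given, a lower number a weaker effect:
Compound 1 `CC(C)[C@H](NC(=O)CN(c1ncnc2c1ncn2C1CCCCO1)C1CC1)C(=O)OCc1ccccc1`: 30.1%
Compound 2 `O=C(CN(c1nc(Cl)nc2[nH]cnc12)C1CC1)NCC(=O)OCc1ccccc1`: 27.2%
Compound 3 `C[C@H](NC(=O)CN(c1nc(Cl)nc2[nH]cnc12)C1CC1)C(=O)OCc1ccccc1`: 44.2%

Compound 1 stands second highest of the three; its number lies within the scatter of compound 2, while compound 3 sits beyond the scatter above it. Compound 4 `CC(C)(C)OC(=O)NCCCC[C@H](NC(=O)CN(c1ncnc2c1ncn2C1CCCCO1)C1CC1)C(=O)OCc1ccccc1` differs from compound 1 by 4-((tert-butoxycarbonyl)amino)butyl in place of isopropyl on a saturated chain carbon bound to an amide-type nitrogen and a carbonyl carbon. Among the compounds with values here, the only measured step at that place is a number 17 percentage points higher from compound 2 to compound 3 (beyond the scatter), a small change in size that gave a modest gain. Within the data shown here, no measured step tells how a much longer chain with a carbamate behaves there, so the expectation rests on little. A change of a number 1.9 percentage points higher from compound 1 to compound 4 (within the scatter) is expected, with compound 4 estimated at 32% in this assay, between 12% and 52%.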

Compound 4, a percentage reported as activity, at one dose (the size of the read-out at that dose, not a potency): 32.9%
Compound 4: middle estimate off by 0.9 percentage points, on the low side; the range from low to high includes it.
By their numbers in this assay, from the lowest: compounds 2, 1 and 4 (each within the scatter of the next); then compound 3.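

In this assay, putting 4-((tert-butoxycarbonyl)amino)butyl in place of isopropyl gives a number 2.8 percentage points higher from compound 1 to compound 4 (within the scatter). This position on the saturated chain carbon therefore takes a group of 12 heavy atoms instead of 3 without a change beyond the scatter, something the small methyl step could not show. Nothing available here explains this tolerance. Still open, as far as these compounds go, is whether a free amine or a carboxylic acid at the end of the butyl chain would read the same. Also open, from the compounds shown here alone, is how this long chain behaves on the core of compound 3.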